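Adding Chloro to the Acrylamide of Compound 2

This account rests on a few compounds, and the source may have more. Where it says the series, first, only, none or still open, it means among the compounds named here.

Measured so far:
- compound 1, `C=C(Cl)C(=O)Nc1cc(Nc2nccc(-c3cn(C)c4ccccc34)n2)c(OC)cc1N(C)CCN(C)C`: 7520 nM
- compound 2, `C=CC(=O)Nc1cc(Nc2nc(C)cc(-c3cn(C)c4ccccc34)n2)c(OC)cc1N(C)CCN(C)C`: 2910 nM

Both compounds were tested in a functional assay on A549 cells (Homo sapiens) for antiproliferative activity, read by MTT assay, with a stated time of 72 h; on this read-out lower numbers stand for stronger inhibition and higher numbers for weaker inhibition. For the measured compounds named here, compound 2 stands at the lowest of the two numbers, and compound 1, its only comparison, sits at a higher number, a gap beyond the usual scatter. Going by the values given here, compound 1 and compound 2 differ in two places at once, so no single step between them can be read.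

Compound 3, `C=C(Cl)C(=O)Nc1cc(Nc2nc(C)cc(-c3cn(C)c4ccccc34)n2)c(OC)cc1N(C)CCN(C)C`, has not yet been measured. It is compound 2 with one change: chloro in place of hydrogen on a double-bonded chain carbon bound to a carbonyl carbon. Compound 1, which also carries this chloro group, gives 7520 nM in this assay, which is the only hint available. On that basis the step of a 1.7-fold higher number from compound 2 to compound 3 (0.24 log units; within the scatter) is expected to lead toward weaker inhibition, modestly. For compound 3 the value is estimated at 5000 nM, with a range from 1500 nM to 15000 nM.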

Compound 3, half-maximal inhibitory concentration: 1730 nM
For compound 3 the middle estimate is 2.9-fold (0.46 log units) above the measured one, and the stated range covers the measured number.
By their numbers in this assay, from the lowest: compounds 3 and 2 (each within the scatter of the next); then compound 1.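

In this assay, for the compounds shown here, chloro in place of hydrogen on a double-bonded chain carbon bound to a carbonyl carbon gives the first comparison of this change in one place (a 1.7-fold lower number from compound 2 to compound 3 (0.23 log units; within the scatter)), so compound 2 and compound 3 cannot be told apart here. The other comparison in one place, methyl in place of hydrogen on an aromatic carbon, is larger (a 4.3-fold lower number from compound 1 to compound 3 (0.64 log units; beyond the scatter)), so among these three compounds the methyl, not the chloro, is the change that separates the numbers. Nothing shown here offers an explanation for either step.

Still open, from the compounds shown here alone, is whether bromo or methyl on that double-bonded chain carbon would also stay within the scatter. Going by these compounds, it is equally open whether ethyl or an amine in place of the methyl on the aromatic carbon would give a step of similar size.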